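Ester in Place of Amide on a Sulfonamide Core

A few compounds are considered here, and "the series" means these few. Any claim that something is new, unique, unknown or untested is made for them only; others in the source may bear on it.

Compound 1 `CC(=O)c1ccc(NC(=O)c2nc(-c3ccccc3)n(-c3ccc(S(N)(=O)=O)cc3)n2)cc1`: 73%
Compound 2 `NC(=O)c1nc(-c2ccccc2)n(-c2ccc(S(N)(=O)=O)cc2)n1`: 52%

Going by the values given here, in a functional assay on the whole organism for inhibition, with Rattus norvegicus as the target, read by paw edema, with stated times of 30 min and 3 h, at a dose of 0.28 mmol/kg by the oral route (on this read-out lower numbers stand for less inhibition and higher numbers for more inhibition at the one dose given (going by the name of the read-out)), compound 1 gives 73% and compound 2 gives 52%, so compound 2 stands lowest of the two measured compounds, with compound 1 as its only neighbour. Among the compounds with values here, the single measured step, a number 21 percentage points lower from compound 1 to compound 2 (beyond the scatter), came with hydrogen in place of 4-acetylphenyl on an amide-type nitrogen. Compound 3 `COC(=O)c1nc(-c2ccccc2)n(-c2ccc(S(N)(=O)=O)cc2)n1` has not yet been measured. It differs from compound 2 by methoxy in place of amino on a carbonyl carbon. Within the data shown here, no measured step touches the carbonyl carbon in this way, and the one known step concerns a different place, so it gives no direction for this change. A shift beyond the scatter in either direction cannot be excluded, but nothing known points to one. For compound 3 the estimate is 52%, with a range from 32% to 72%. The step this expectation implies, no change at the digits printed from compound 2 to compound 3 (within the scatter), is expected to stay within the scatter.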

Compound 3, a percentage reported as inhibition, in the whole organism at one dose (the size of the read-out at that dose, not a potency): 69%
Estimate against measurement, compound 3: 17 percentage points below, within the range that was stated.
By their numbers in this assay, from the lowest: compound 2; then compounds 3 and 1 (each within the scatter of the next).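

In this assay, the carbonyl carbon proves to be a place that responds to change, since methoxy in place of amino gives a number 17 percentage points higher from compound 2 to compound 3 (beyond the scatter) and so moves the read-out as clearly as the earlier change on the amide-type nitrogen did. Methoxy in place of (4-acetylphenyl)amino gives a number 4 percentage points lower from compound 1 to compound 3 (within the scatter) and leaves the two compounds indistinguishable, so at this one dose the 4-acetylphenyl group is not needed to reach this level of inhibition once methoxy sits on the carbonyl carbon. No measurement shown here explains the shift between amino and methoxy.

The compounds shown leave open how a carboxylic acid or a longer chain such as ethoxy on the same carbonyl carbon would read. They also leave open whether a methylamino group would behave like amino or like methoxy.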